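Replacing Pyridinyl by Pyrimidinyl on the Piperazine Arm

The compounds below may be only part of what the source reports. "The series", "measured", "known", "first", "only" and "open" are said of these compounds alone.

Measured compounds:
- compound 1, `Nc1ccccc1NC(=O)c1ccc(CSC(=S)N2CCc3ccccc32)cc1`: 87%
- compound 2, `Nc1ccccc1NC(=O)c1ccc(CSC(=S)N2CCN(c3cccnc3)CC2)cc1`: 76.9%
- compound 3, `CC1CCCCN1C(=S)SCc1ccc(C(=O)Nc2ccccc2N)cc1`: 86.9%

In a functional assay on MGC-803 cells (Homo sapiens) for antiproliferative activity, read by CCK-8 assay, with a stated time of 72 h, tested at 8 uM (a lower number here means a weaker effect, a higher number a stronger effect of the compound at the concentration tested), compound 2 has the lowest number of the three, though its gap to compound 3 lies within the scatter; only compound 1 stands beyond it. Compound 4, `Nc1ccccc1NC(=O)c1ccc(CSC(=S)N2CCN(c3ncccn3)CC2)cc1`, differs from compound 2 by pyrimidin-2-yl in place of pyridin-3-yl on an amine nitrogen in a ring. For the measured compounds named here, the only measured step, a number 0.1 percentage points lower from compound 1 to compound 3 (within the scatter), concerns a different part of the shared core and so does not bear on this change; no measured pair tells how a swap on the amine nitrogen in the ring affects this assay. With nothing to point either way, the expected step of a number 0.1 percentage points higher from compound 2 to compound 4 (within the scatter) is none beyond the scatter. Compound 4 is therefore estimated at 77%, within 62% to 90%.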

Compound 4, a percentage reported as inhibition, at one concentration (the size of the read-out at that concentration, not a potency): 64.8%
For compound 4 the middle estimate is 12.2 percentage points above the measured one; measured number inside the range.
By their numbers in this assay, from the lowest: compound 4; then compounds 2, 3 and 1 (each within the scatter of the next, the first and the last beyond it).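

This first measured change on the amine nitrogen in the ring shows that the group held there matters in this assay: the swap gives a number 12.1 percentage points lower from compound 2 to compound 4 (beyond the scatter). Both groups are six-membered aromatic rings with the same heavy-atom count, so the step comes without any change in ring size. No measurement available here explains the step. Still open, from the compounds shown here alone, is whether it follows the added ring nitrogen or the point of attachment; pyridin-2-yl would help separate the two, and plain phenyl would show the effect of a ring without nitrogen.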